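This account rests on a few compounds, and the source may have more. Where it says the series, first, only, none or still open, it means among the compounds named here.

In a functional assay for inhibition, with Homo sapiens as the target (a lower number here means a stronger inhibitor, a higher number a weaker inhibitor), compound 1 `COc1cccc(/C=C/C(=O)c2c(OC)cc(OC)cc2OC)c1` gives 1800 nM and compound 2 `COc1cc(OC)c(C(=O)/C=C/c2ccccn2)c(OC)c1` gives 596 nM, the lower of the two numbers and so the stronger inhibitor of this pair. Compound 3 `COc1cc(OC)c(C(=O)/C=C/c2cnccn2)c(OC)c1` has not yet been measured. It differs from compound 2 in one place, with pyrazin-2-yl in place of pyridin-2-yl on a double-bonded chain carbon bound to a double-bonded chain carbon. Among the measured compounds shown here, only one measured step touches this place, a 3.0-fold lower number from compound 1 to compound 2 (0.48 log units; beyond the scatter), a modest change in which pyridin-2-yl replaced 3-methoxyphenyl. For the measured compounds named here, no measurement yet shows what the swap to pyrazin-2-yl does, so that step suggests a rough size but no firm direction. The expected change in this assay is small and stays within the scatter, an estimated 1.2-fold higher number from compound 2 to compound 3 (0.07 log units; within the scatter). For compound 3 the estimated value is 700 nM, with an expected range from 250 nM to 2000 nM.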

Compound 3, half-maximal inhibitory concentration: 693 nM
For compound 3 the middle estimate is 1.0-fold (0.00 log units) above the measured one, and the stated range covers the measured number.
By their numbers in this assay, from the lowest: compounds 2 and 3 (each within the scatter of the next); then compound 1.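

In this assay, pyrazin-2-yl in place of pyridin-2-yl brings a second ring nitrogen and a second hydrogen-bond acceptor, yet the step is within the scatter (a 1.2-fold higher number from compound 2 to compound 3 (0.07 log units; within the scatter)), so this assay does not tell the two rings apart. The lower number seen with pyridin-2-yl therefore also appears with a second nitrogen-containing ring at this place on the chain, as pyrazin-2-yl also stands clearly apart from 3-methoxyphenyl (a 2.6-fold lower number from compound 1 to compound 3 (0.41 log units; beyond the scatter)). No supporting evidence is available to explain either step.

Still open, going by these compounds, is whether the ring nitrogen or the loss of the methoxy group accounts for the lower numbers, a question that a plain phenyl ring at this place could separate. Also open, on these data alone, is how a ring carrying an amine or a carboxylic acid would read here.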